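One Added Methoxy Group, Two Related Compound Pairs

This account rests on a few compounds, and the source may have more. Where it says the series, first, only, none or still open, it means among the compounds named here.

Three compounds have been measured in a functional assay on MDA-MB-231 cells (Homo sapiens) for antiproliferative activity, read by sulforhodamine B assay, with a stated time of 48 h; a higher number here means a weaker inhibitor, a lower number a stronger inhibitor:

Compound 1 `COc1cc(OC)c2sc(-c3ccc(N/C=C\C(=O)c4cc(OC)c(OC)c(OC)c4Br)c(C)c3)nc2c1` gives 17300 nM.
Compound 2 `COc1ccc(C(=O)/C=C\Nc2ccc(-c3nc4cc(OC)c(OC)c(OC)c4s3)cc2)cc1[N+](=O)[O-]` gives 17100 nM.
Compound 3 `COc1cc(C(=O)/C=C\Nc2ccc(-c3nc4cc(OC)c(OC)c(OC)c4s3)cc2)cc([N+](=O)[O-])c1OC` gives 9800 nM.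

Compound 2 and compound 3 differ in one place: methoxy in place of hydrogen on an aromatic carbon. The measured step is a 1.7-fold lower number from compound 2 to compound 3 (0.24 log units; within the scatter), so the added methoxy group left the number essentially unchanged. Compound 1 and compound 2 share much of their structure, but the difference between the two cores is not broken down here; their values stand within the scatter of each other.

The unmeasured compound 4 `COc1cc(C(=O)/C=C\Nc2ccc(-c3nc4cc(OC)c(OC)c(OC)c4s3)cc2C)c(Br)c(OC)c1OC` is derived from compound 1 by the same kind of change: methoxy in place of hydrogen on an aromatic carbon. It is not the same change, since here the receiving carbon is ortho to two methoxy groups, meta to a fused ring and para to a fused ring, whereas in the earlier pair it was ortho to a methoxy group, meta to a large group and meta to a nitro group.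

The expected step from compound 1 to compound 4 is a 1.6-fold lower number from compound 1 to compound 4 (0.20 log units; within the scatter), an estimate that rests on the earlier step of a 1.7-fold lower number from compound 2 to compound 3 (0.24 log units; within the scatter). Compound 4 is therefore expected to give about 11000 nM in this assay. The estimated range for compound 4 runs from 4000 nM to 30000 nM.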

Compound 4, half-maximal inhibitory concentration: 7300 nM
Estimate against measurement, compound 4: 1.5-fold (0.18 log units) above; measured number inside the range.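

In this assay, a methoxy group in place of hydrogen on an aromatic carbon gave a 2.4-fold lower number from compound 1 to compound 4 (0.37 log units; beyond the scatter). Both pairs with this kind of change moved in the same direction, and the size of the step carried over from one core to the other as closely as the scatter of such measurements can show: the same change on two cores in this assay, a 1.7-fold lower number (0.24 log units; within the scatter) from compound 2 to compound 3 and a 2.4-fold lower number (0.37 log units; beyond the scatter) from compound 1 to compound 4, 1.4-fold (0.13 log units) apart, within the scatter of two such steps. Among these compounds, this does not establish a general rule, since it rests on only two pairs, the receiving carbon has different surroundings in each, and the earlier step on its own cannot be told apart from scatter.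

The compounds shown leave open whether the step would hold on a third core. They also leave open how a hydroxyl group, an ethoxy group or an amine on the same carbon would compare with methoxy.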